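Methyl in Place of Fluoro in Compound 3

The source may report more compounds than this note shows. Statements on the series, on what has been measured and on what is new or still open speak of the compounds shown alone.

In a functional assay on SK-OV-3 cells (Homo sapiens) for antiproliferative activity, read by MTT assay, with a stated time of 72 h (a lower number here means a stronger inhibitor, a higher number a weaker inhibitor), compound 1 (`CC(C)(C)NC(=O)CCc1cccc2c1B(O)OC2`) gives > 100000 nM, which is a limit of the assay. Compound 2 (`O=C(CCc1cccc2c1B(O)OC2)NCc1ccccc1`) gives > 100000 nM, also a limit. Compound 3 (`O=C(CCc1cccc2c1B(O)OC2)Nc1ccc(F)cc1`) alone reaches a measured number, 720 nM. Compound 4 (`Cc1ccc(NC(=O)CCc2cccc3c2B(O)OC3)cc1`) differs from compound 3 at one place: methyl in place of fluoro on an aromatic carbon. Within the data shown here, two measured steps bear on this, an at least 130-fold lower number from compound 1 to compound 3 (2.14 log units; beyond the scatter) and an at least 130-fold lower number from compound 2 to compound 3 (2.14 log units; beyond the scatter). Both are large, but both change the whole group on the amide-type nitrogen, whereas the new change keeps the ring. No step beyond the scatter is therefore expected, and the estimated step is a 1.4-fold higher number from compound 3 to compound 4 (0.14 log units; within the scatter). The estimate for compound 4 is 1000 nM, with an expected range of 300 nM to 5000 nM.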

Compound 4, half-maximal inhibitory concentration: 860 nM
Beside the measured number, compound 4's estimate is 1.2-fold (0.07 log units) above it, within the range that was stated.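

In this assay, methyl in place of fluoro at this ring position stays within the scatter, a 1.2-fold higher number from compound 3 to compound 4 (0.08 log units; within the scatter), so the measurable activity of the aryl amide does not depend on fluoro alone. The 4-methylphenyl group also keeps a large separation from the other two amide groups, an at least 110-fold lower number from compound 2 to compound 4 (2.06 log units; beyond the scatter) and an at least 110-fold lower number from compound 1 to compound 4 (2.06 log units; beyond the scatter). Both of these steps start from a limit of the assay, so their full size cannot be read: the limit of > 100000 nM in this assay, at which 2 of the 4 values shown sit.

The compounds shown leave open whether an amine, a carboxylic acid or a methoxy group at this place would keep the number in the same region. They also leave open how a longer chain between the amide and the shared core would act.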